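The source may hold more compounds than are shown below. What is called first, only, known or untested is meant among the compounds shown, and "the series" means these compounds.

Compound 1 `CCCCN(C)c1cc(C(F)(F)F)ccc1CNC(=O)C(C)c1ccc(NS(C)(=O)=O)c(F)c1` gives 1.2 nM in an assay on CHO cells for antagonist activity at transient receptor potential cation channel subfamily V member 1 (Homo sapiens), read by FLIPR (a higher number here means a weaker inhibitor, a lower number a stronger inhibitor), the highest of the three numbers in hand. Compound 2 `CC1CCN(c2cc(C(F)(F)F)ccc2CNC(=O)C(C)c2ccc(NS(C)(=O)=O)c(F)c2)CC1` gives 0.9 nM, and compound 3 `CC(C(=O)NCc1ccc(C(F)(F)F)cc1OC1CCCC1)c1ccc(NS(C)(=O)=O)c(F)c1` gives 0.6 nM; the steps of a 1.3-fold lower number from compound 1 to compound 2 (0.12 log units; within the scatter) and a 2.0-fold lower number from compound 1 to compound 3 (0.30 log units; within the scatter) both stay within the scatter, as does a 1.5-fold lower number from compound 2 to compound 3 (0.18 log units; within the scatter). Compound 4 `CC(C(=O)NCc1ccc(C(F)(F)F)cc1SC1CCCCC1)c1ccc(NS(C)(=O)=O)c(F)c1` differs from compound 1 by cyclohexylsulfanyl in place of butyl(methyl)amino on an aromatic carbon. The step to compound 3 bears most on this: compound 3 likewise carries a ring on that aromatic carbon. The step to compound 2 is the other comparison. Both were small, so no step beyond the scatter is expected in this assay, if anything a slightly lower number. Compound 4 is thus estimated at 0.7 nM, with a range of 0.3 nM to 1.8 nM, an expected step of a 1.7-fold lower number from compound 1 to compound 4 (0.23 log units; within the scatter).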

Compound 4, inhibition constant: 0.5 nM
Beside the measured number, compound 4's estimate is 1.4-fold (0.15 log units) above it; the measured number falls inside the stated range.
By their numbers in this assay, from the lowest: compounds 4, 3, 2 and 1 (each within the scatter of the next, the first and the last beyond it).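

For the compounds shown here, at this aromatic carbon, meta to a trifluoromethyl group, cyclohexylsulfanyl gives the first step beyond the scatter in this assay (a 2.4-fold lower number from compound 1 to compound 4 (0.38 log units; beyond the scatter)), though a modest one. Against the other two ring-bearing groups it stays within the scatter (a 1.2-fold lower number from compound 3 to compound 4 (0.08 log units; within the scatter)) and (a 1.8-fold lower number from compound 2 to compound 4 (0.26 log units; within the scatter)), so these three compounds are not separated. Nothing measured on hand accounts for the step from the open-chain butyl(methyl)amino group.

From the compounds shown here alone, whether a carboxylic acid, a primary amine or an open-chain butylsulfanyl on this carbon would keep the number this low remains open. Also open, going by these compounds, is whether the sulfur or the ring carries the step.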